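The compounds below may be only part of what the source reports. "The series", "measured", "known", "first", "only" and "open" are said of these compounds alone.

Of the compounds shown here, three sharing one core have been tested in a functional assay on HepG2 cells (Homo sapiens) for antiproliferative activity, read by MTT assay, with a stated time of 72 h; on this read-out lower numbers stand for stronger inhibition and higher numbers for weaker inhibition. Compound 1 `NC1=NC2(CCSCC2)N(OCCCOc2ccc(Cl)c(Cl)c2)C(N)=N1` gives 70 nM, compound 2 `NC1=NC2(CCSCC2)N(OCCCOc2ccccc2Br)C(N)=N1` gives 90 nM and compound 3 `NC1=NC2(CCSCC2)N(OCCCOc2ccccc2Cl)C(N)=N1` gives 80 nM, so compound 3 stands within the scatter of both others. Compound 4 `NC1=NC2(CCSCC2)N(OCCCOc2cccc(Br)c2)C(N)=N1` differs from compound 3 in one place: 3-bromophenyl in place of 2-chlorophenyl on an oxygen on a saturated carbon. In words, 3-bromophenyl takes the place of 2-chlorophenyl on an oxygen on a saturated carbon. Going by the values given here, three measured steps bear on this change. Chloro in place of bromo gave a 1.1-fold lower number from compound 2 to compound 3 (0.05 log units; within the scatter), while replacing 3,4-dichlorophenyl gave a 1.3-fold higher number from compound 1 to compound 2 (0.11 log units; within the scatter) and a 1.1-fold higher number from compound 1 to compound 3 (0.06 log units; within the scatter). All three are small, so no step beyond the scatter is expected in this assay. The expected step is a 1.1-fold higher number from compound 3 to compound 4 (0.03 log units; within the scatter). Compound 4 is estimated at 85 nM, with an expected range of 45 nM to 170 nM.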

Compound 4, half-maximal inhibitory concentration: 90 nM
The estimate for compound 4 lay 1.1-fold (0.02 log units) below the measured number; measured number inside the range.
By their numbers in this assay, from the lowest: compounds 1, 3, 2 and 4 (each within the scatter of the next).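

In this assay, 3-bromophenyl in place of 2-chlorophenyl gave a 1.1-fold higher number from compound 3 to compound 4 (0.05 log units; within the scatter), in place of 2-bromophenyl it gave no change at the digits printed from compound 2 to compound 4 (within the scatter), and in place of 3,4-dichlorophenyl it gave a 1.3-fold higher number from compound 1 to compound 4 (0.11 log units; within the scatter). Bromo was previously seen only in 2-bromophenyl, and 3-bromophenyl now shows that a different bromophenyl also stays within the scatter of every earlier compound. No measurement here explains this lack of change. From the compounds shown here alone, it remains open whether an amine or a carboxylic acid on the phenyl ring, or a longer chain in place of the present one, would shift the number.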